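This account rests on a few compounds, and the source may have more. Where it says the series, first, only, none or still open, it means among the compounds named here.

For the measured compounds named here, compound 1 `CC(C)C(Nc1nnc[nH]1)c1ccc(-c2ccc3cccc(F)c3c2)[nH]c1=O` stands highest of the three measured members in an ADME assay on microsomes from liver (Rattus norvegicus) for metabolic stability (a higher number here means that the compound lasts longer, a lower number that the compound disappears faster), where compound 1 gives 1.29 h. Compound 2 `CC(C)C(Cc1nnc[nH]1)c1ccc(-c2ccc3cccc(F)c3c2)[nH]c1=O` gives 0.1 h and compound 3 `CC(C)C(c1ccc(-c2ccc3cccc(F)c3c2)[nH]c1=O)N1CCN/C1=N\C#N` gives 0.327 h, so each change so far has cost stability: a 13-fold lower number from compound 1 to compound 2 (1.11 log units; beyond the scatter); a 3.9-fold lower number from compound 1 to compound 3 (0.60 log units; beyond the scatter). Compound 4 `Cc1c[nH]c(C(c2ccc(-c3ccc4cccc(F)c4c3)[nH]c2=O)C(C)C)n1` carries 4-methyl-1H-imidazol-2-yl in place of (4H-1,2,4-triazol-3-yl)amino on a saturated chain carbon bound to an aromatic carbon and a saturated chain carbon. Both measured steps bear on it: like compound 2, compound 4 no longer has the (4H-1,2,4-triazol-3-yl)amino group, and like compound 3 it carries a different ring in its place. The step to compound 2 was large and the step to compound 3 modest, so a drop beyond the scatter, between those two sizes, is expected: a 5.2-fold lower number from compound 1 to compound 4 (0.71 log units; beyond the scatter). Compound 4 is estimated at 0.25 h, with a range from 0.1 h to 0.7 h.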

Compound 4, half-life: < 0.0667 h
Compound 4 gave a limit, no number (the forecaster's own chance of this, stated with the estimate: 5%); middle value at least 3.7-fold (0.57 log units) away from the limit.
By their numbers in this assay, from the lowest: compound 2; then compound 3; then compound 1. At a limit, below all of these: compound 4.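

In this assay compound 4 gives a limit, not a number: the limit of < 0.0667 h in this assay, at which 1 of the 4 values shown sits.

On this saturated chain carbon, 4-methyl-1H-imidazol-2-yl gives an at least 19-fold lower number from compound 1 to compound 4 (1.28 log units; beyond the scatter) and an at least 4.9-fold lower number from compound 3 to compound 4 (0.69 log units; beyond the scatter), so a five-membered aromatic ring at this place does not by itself keep the half-life. The step of an at least 1.4-fold lower number from compound 2 to compound 4 (0.17 log units; that floor lies within the scatter) cannot be read as a difference.

Still open, on these data alone, is whether the half-life of the (4H-1,2,4-triazol-3-yl)amino compound depends on the ring or on the amino link, and how a simple amine or a carboxylic acid would behave at this place.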